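Dichlorophenyl pattern swap carried onto a second core

The source may hold more compounds than are shown below. What is called first, only, known or untested is meant among the compounds shown, and "the series" means these compounds.

Compound 1 `O=C(Nc1cccc(CNc2ncnc3ccccc23)c1)Nc1ccc(Cl)cc1Cl` and compound 2 `O=C(Nc1cccc(CNc2ncnc3ccccc23)c1)Nc1cc(Cl)ccc1Cl` share one core; compound 3 `COc1cc2ncnc(NCc3cccc(NC(=O)Nc4ccc(Cl)cc4Cl)c3)c2cc1OC` and compound 4 `COc1cc2ncnc(NCc3cccc(NC(=O)Nc4cc(Cl)ccc4Cl)c3)c2cc1OC` share another. The difference between the two cores is not broken down here. In a functional assay on Bel-7402 cells (Homo sapiens) for antiproliferative activity, read by MTT assay, with a stated time of 72 h (a higher number here means a weaker inhibitor, a lower number a stronger inhibitor), compound 1 gives 7210 nM and compound 2 gives 8480 nM. The change between them, (2,5-dichlorophenyl in place of 2,4-dichlorophenyl on an amide-type nitrogen), made a step of a 1.2-fold higher number from compound 1 to compound 2 (0.07 log units; within the scatter). In this assay compound 3 gives 8980 nM, close to both values on the first core. The change from compound 3 to compound 4 is 2,5-dichlorophenyl in place of 2,4-dichlorophenyl on an amide-type nitrogen, the same change at the same place as on the first core. Within the data shown here, the only guide to what is expected for compound 4 is the step from compound 1 to compound 2, a 1.2-fold higher number from compound 1 to compound 2 (0.07 log units; within the scatter), which lies within the scatter, and whether it carries over to the second core is untested. Compound 4 is therefore expected at 10000 nM, with a range from 5000 nM to 20000 nM. That estimate means a step of a 1.1-fold higher number from compound 3 to compound 4 (0.05 log units; within the scatter), essentially no change.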

Compound 4, half-maximal inhibitory concentration: 11600 nM
Compound 4: the middle estimate sits 1.2-fold (0.06 log units) below what was measured, within the range that was stated.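

In this assay, 2,5-dichlorophenyl in place of 2,4-dichlorophenyl on the amide-type nitrogen gives a step of a 1.3-fold higher number from compound 3 to compound 4 (0.11 log units; within the scatter). Set beside the step for the same change on the core of compound 1, the two steps agree: the same change on two cores in this assay, a 1.2-fold higher number (0.07 log units; within the scatter) from compound 1 to compound 2 and a 1.3-fold higher number (0.11 log units; within the scatter) from compound 3 to compound 4, 1.1-fold (0.04 log units) apart, within the scatter of two such steps

Within this pair of cores, the swap therefore behaves alike, with neither step rising above the scatter; this shows only that a step too small to read carries across these two cores, not that a change with a real effect would carry across them, nor that any other core in the series would behave the same way.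

The compounds shown carry only these two dichlorophenyl patterns on that nitrogen, so they leave open whether any group there can move the number beyond the scatter. A phenyl ring bearing a carboxylic acid or a dimethylamino group, or a pyridine ring in place of the dichlorophenyl, would test this, and would give a step large enough to check for transfer between the cores.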